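The source may report more compounds than this note shows. Statements on the series, on what has been measured and on what is new or still open speak of the compounds shown alone.

Measured so far:
- compound 1, `CCCCNC(=N)NCCCC`: 750 nM
- compound 2, `Cc1cc([N+](=O)[O-])ccc1/N=C(/N)Nc1cccc(O)c1`: 118 nM
- compound 3, `Cc1ccccc1/N=C(/N)Nc1ccccc1I`: 21 nM

All three were tested in an assay on membranes from brain (Cavia porcellus) for binding affinity to Sigma non-opioid intracellular receptor 1 (Homo sapiens); a lower number here means a stronger inhibitor, a higher number a weaker inhibitor. Compound 3 has the lowest number of the three and is thus the strongest binder here: the gap up to compound 2 lies beyond the usual scatter, and the gap up to compound 1 is larger still. Compound 1, a simple chain-bearing guanidine, is the weakest of the set.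

The next compound, compound 4, `Cc1ccccc1/N=C(/N)Nc1ccccc1N`, is built from compound 3 by a single change: amino in place of iodo on an aromatic carbon. Among the compounds with values here, no two measured compounds differ from each other in only one place, so nothing already measured shows what such a swap does in this assay. The expectation is therefore a judgement call. A weakening of binding, somewhat beyond the scatter, is expected: a 7.1-fold higher number from compound 3 to compound 4 (0.85 log units; beyond the scatter). Compound 4 is accordingly estimated to give about 150 nM in this assay, most likely somewhere between 40 nM and 600 nM.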

Compound 4, half-maximal inhibitory concentration: 463 nM
For compound 4 the middle estimate is 3.1-fold (0.49 log units) below the measured one; the measured number falls inside the stated range.
By their numbers in this assay, from the lowest: compound 3; then compound 2; then compounds 4 and 1 (each within the scatter of the next).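

Within the data shown here, this pair gives the first direct reading of a single swap in this assay: amino in place of iodo on an aromatic carbon, ortho to a large group, brings a 22-fold higher number from compound 3 to compound 4 (1.34 log units; beyond the scatter), a large step beyond the scatter. The position is thus sensitive to which group it carries, even though each group counts one heavy atom; what differs in the count is that amino brings one hydrogen-bond donor and one hydrogen-bond acceptor, and iodo brings neither. No measurement at hand bears on the cause of this step.

As far as these compounds go, it remains open whether the step reflects the departure of iodo or the arrival of amino. A chloro, a hydroxyl or a methoxy group on the same aromatic carbon would help to tell these two readings apart.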